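Swapping fluorines for a nitrile on the benzyl arm

This account rests on a few compounds, and the source may have more. Where it says the series, first, only, none or still open, it means among the compounds named here.

Measured so far:
- compound 1, `O=C(O)c1ccccc1-c1ccc(CCc2ncc(CC3CCC3)[nH]2)cc1`, 588 nM
- compound 2, `O=C(O)c1ccccc1-c1ccc(CCc2ncc(Cc3cccc(F)c3F)[nH]2)cc1`, 87 nM

Among the compounds with values here, in an in vitro functional assay on cells for agonist activity at Bombesin receptor subtype-3 (Homo sapiens), read by luminescence and calcium flux (a lower number here means that less compound is needed, a higher number that more compound is needed for the effect), compound 2 gives 87 nM, the lowest of the two numbers so far, and its only neighbour is compound 1 at 588 nM. Within the data shown here, the one measured step, a 6.8-fold lower number from compound 1 to compound 2 (0.83 log units; beyond the scatter), replaced cyclobutyl with 2,3-difluorophenyl on a saturated chain carbon bound to an aromatic carbon. Compound 3, `N#Cc1ccccc1Cc1cnc(CCc2ccc(-c3ccccc3C(=O)O)cc2)[nH]1`, keeps that aromatic ring and changes only its decoration: 2-cyanophenyl in place of 2,3-difluorophenyl on a saturated chain carbon bound to an aromatic carbon. This is a smaller change than the measured step, which swapped a saturated ring for an aromatic one, so that step speaks only loosely here. Among the measured compounds shown here, no measured pair shows what a nitrile does in this position. The expectation for compound 3 is therefore a step of about a 1.5-fold higher number from compound 2 to compound 3 (0.17 log units; within the scatter), possibly none beyond the scatter, leaning toward a slightly higher number. The estimate for compound 3 in this assay is 130 nM, within 40 nM to 400 nM.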

Compound 3, half-maximal effective concentration: 5480 nM
Estimate against measurement, compound 3: 42-fold (1.62 log units) below; the whole stated range lies below it.
By their numbers in this assay, from the lowest: compound 2; then compound 1; then compound 3.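

In this assay, this position proves far more sensitive to what the aromatic ring carries than the first pair could show: keeping the ring and changing only its decoration gives a 63-fold higher number from compound 2 to compound 3 (1.80 log units; beyond the scatter). An aromatic ring here therefore does not by itself bring a lower number, since replacing cyclobutyl gives a 6.8-fold lower number from compound 1 to compound 2 (0.83 log units; beyond the scatter) with 2,3-difluorophenyl but a 9.3-fold higher number from compound 1 to compound 3 (0.97 log units; beyond the scatter) with 2-cyanophenyl. Nothing available explains why these two decorated rings differ so much.

As far as these compounds go, it remains open whether the fluorines lower the number, the nitrile raises it, or both, as a plain phenyl ring on this carbon would help to show. Also unknown is how other ring decorations, such as a chlorine or a methoxy group, would compare with compound 2 and compound 3.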